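The compounds below may be only part of what the source reports. "The series", "measured", "known", "first", "only" and "open" are said of these compounds alone.

The measured compounds:

Compound 1, `COc1nc(=O)n(C)c(CC(F)(COC(C)=O)COC(C)=O)c1C`, in a functional assay on HepG2 cells (Homo sapiens) for antiproliferative activity, read by MTT assay, with a stated time of 72 h (on this read-out higher numbers stand for weaker inhibition and lower numbers for stronger inhibition), gives > 100000 nM, which is a limit of the assay and not a number.
Compound 2, `COc1nc(=O)n(C)c(CC(O)(COC(C)=O)COC(C)=O)c1C`, in this assay gives > 100000 nM, again a limit rather than a number.
Compound 3, `CC(=O)OCC(O)(COC(C)=O)Cc1c(C)c(=O)[nH]c(=O)n1C`, in this assay gives > 100000 nM, once more a limit.

Compound 4, `CC(=O)OCC(F)(COC(C)=O)Cc1c(C)c(=O)[nH]c(=O)n1C`, has not yet been measured in this assay.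

From compound 2 to compound 1 the change is fluoro in place of hydroxy on a saturated chain carbon bound to three saturated chain carbons. The step that the two limits leave unreadable from compound 2 to compound 1 cannot be read, because of the limit of > 100000 nM in this assay, at which 3 of the 3 values shown sit. From compound 3 to compound 4 the change is fluoro in place of hydroxy on a saturated chain carbon bound to three saturated chain carbons, the same change at the same kind of place. How the core of compound 3 differs from that of compound 2 is not broken down here.

Within the data shown here, for compound 4 the step that the limit leaves unreadable from compound 3 to compound 4 is expected to be just as unreadable, since the one measured example of this change starts and ends at a limit. Compound 4 is therefore expected to give 200000 nM, with a range from 50000 nM to 1000000 nM, and most probably the assay will again report only a limit for compound 4.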

Compound 4, half-maximal inhibitory concentration: > 100000 nM
Compound 4 gave a limit, no number (the forecaster's own chance of this, stated with the estimate: 85%); the middle value is on the limit's open side.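

No new step can be read from the pair compound 3 and compound 4, because each of them gives only a limit and not a number: the limit of > 100000 nM in this assay, at which 4 of the 4 values shown sit.

The compounds shown leave open whether fluoro in place of hydroxy changes anything in this assay, and how strongly, if at all, any of these four compounds inhibits there.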